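The source may report more compounds than this note shows. Statements on the series, on what has been measured and on what is new or still open speak of the compounds shown alone.

Compound 1 `CCC1=C(O)c2c(oc(-c3ccc(Br)cc3)cc2=O)C(CC)(CC)C1=O` reaches only a limit in a functional assay on KB cells (Homo sapiens) for antiproliferative activity, read by sulforhodamine B assay, with a stated time of 3 days (on this read-out higher numbers stand for an effect only at larger amounts of compound and lower numbers for an effect already at smaller amounts), > 48.1 uM. Compound 2 `CCC1=C(O)c2c(oc(-c3ccc(COC)cc3)cc2=O)C(CC)(CC)C1=O` also gives a limit, > 52.4 uM. For the measured compounds named here, compound 3 `CCC1=C(O)c2c(oc(-c3cccc(OC)c3)cc2=O)C(CC)(CC)C1=O` gives 13.3 uM, the one true number so far. Compound 4 `CCC1=C(O)c2c(oc(-c3ccccc3F)cc2=O)C(CC)(CC)C1=O` carries 2-fluorophenyl in place of 3-methoxyphenyl on an aromatic carbon, next to the ring oxygen: 2-fluorophenyl in place of 3-methoxyphenyl on an aromatic carbon. Two measured steps exchange this same aryl group, an at least 3.6-fold lower number from compound 1 to compound 3 (0.55 log units; beyond the scatter) and an at least 3.9-fold lower number from compound 2 to compound 3 (0.59 log units; beyond the scatter), and both lie beyond the scatter. Both compounds without 3-methoxyphenyl thus sit at higher readings, although neither carries fluorine, so a modest rise is expected in this assay. The expected change is a 2.1-fold higher number from compound 3 to compound 4 (0.32 log units; beyond the scatter). For compound 4 the estimate is 28 uM, with an expected range of 10 uM to 60 uM.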

Compound 4, concentration for half-maximal effect: > 56.2 uM
Compound 4 was reported as a limit; the forecaster's own chance of this, stated with the estimate: 35%; middle value at least 2.0-fold (0.30 log units) away from the limit.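

In this assay, 2-fluorophenyl in place of 3-methoxyphenyl brings an at least 4.2-fold higher number from compound 3 to compound 4 (0.62 log units; beyond the scatter). Compound 4 stands as a limit and not a number: the limit of > 56.2 uM in this assay, at which 1 of the 4 values shown sits. A third aryl group thus joins 4-bromophenyl and 4-(methoxymethyl)phenyl at a limit, 3-methoxyphenyl alone gives a true number at this position, and the steps among compounds 1, 2 and 4 cannot be read.

Open, from the compounds shown here alone, is whether the number of compound 3 follows the methoxy group itself or its place on the phenyl ring; 4-methoxyphenyl and 3-fluorophenyl would separate the two. Also open, going by these compounds, is how 3-aminophenyl, carrying an amine, would read.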